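A Pyridine Swap on a Core That Tolerates Much

A few compounds are considered here, and "the series" means these few. Any claim that something is new, unique, unknown or untested is made for them only; others in the source may bear on it.

Of the compounds shown here, three sharing one core have been tested in an ADME assay on HCT-116 cells (Homo sapiens) for cytotoxicity, read by MTT assay; a lower number here means that less compound is tolerated, a higher number that more compound is tolerated. Compound 1 `Cc1nc(-c2cccnc2)sc1-c1nnc(-c2ccc([N+](=O)[O-])cc2)o1` carries a nitrophenyl on the shared core; in this assay compound 1 gives > 100 ug/mL, which is a limit of the assay and not a number. Compound 2 `Cc1nc(-c2cccnc2)sc1-c1nnc(-c2ccccc2)o1` has hydrogen in place of the nitro; compound 2 gives > 100 ug/mL, again only a limit. Compound 3 `Cc1nc(-c2cccnc2)sc1-c1nnc(-c2cccc(Cl)c2Cl)o1` bears a 2,3-dichlorophenyl instead; compound 3 gives > 100 ug/mL, likewise a limit. The step that the two limits leave unreadable from compound 1 to compound 2 and the step that the two limits leave unreadable from compound 2 to compound 3 cannot be sized, because of the limit of > 100 ug/mL in this assay, at which 3 of the 3 values shown sit. Compound 3 therefore stands level with the other two, as far as the limits show. Compound 4 `Cc1nc(-c2cccnc2)sc1-c1nnc(-c2ccncc2)o1` is the next change: pyridin-4-yl in place of 2,3-dichlorophenyl on an aromatic carbon. Neither measured step can be read, so the expectation rests only on the fact that three differing groups at this place all gave a limit in this assay. Compound 4 is therefore expected to show no movement beyond the scatter, a step that the limit leaves unreadable from compound 3 to compound 4. Compound 4 is estimated at 150 ug/mL, within the range 60 ug/mL to 400 ug/mL, most likely again reported only as a limit.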

Compound 4, half-maximal cytotoxic concentration: > 100 ug/mL
Compound 4: only a limit was reported; the forecaster's own chance of this, stated with the estimate: 85%; the middle value lies beyond the limit too.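

The steps from compound 2 and from compound 3 to compound 4 cannot be read, because each of these compounds gives only a limit: the limit of > 100 ug/mL in this assay, at which 4 of the 4 values shown sit.

The compounds shown leave open what concentration of any of them the cells actually tolerate in this assay, and whether any group at this place changes it.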